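Nitro for methyl on the aryl arm of compound 2

The compounds below may be only part of what the source reports. "The series", "measured", "known", "first", "only" and "open" are said of these compounds alone.

Two members of the series have numbers in a physicochemical assay for lipophilicity; a lower number here means a more polar compound, a higher number a more lipophilic compound. Compound 1 `C[C@H]1CC[C@@H]2[C@@H](OC(=O)[C@]23CC(c2ccccc2[N+](=O)[O-])=NO3)[C@]2(C)C(=O)C=C[C@@]12O` gives 1.37 in this assay. Compound 2 `Cc1ccc(C2C[C@@]3(ON2c2ccccc2)C(=O)O[C@@H]2[C@H]3CC[C@H](C)[C@]3(O)C=CC(=O)[C@@]23C)cc1` gives 3.64 in this assay, the higher of the two values, and the gap to compound 1 lies beyond the scatter; no single-point change links those two compounds, so their values are only placed side by side.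

Compound 3 `C[C@H]1CC[C@@H]2[C@@H](OC(=O)[C@]23CC(c2ccc([N+](=O)[O-])cc2)N(c2ccccc2)O3)[C@]2(C)C(=O)C=C[C@@]12O` is not yet measured in this assay. Its difference from compound 2 is nitro in place of methyl on an aromatic carbon, that is, 4-methylphenyl becomes 4-nitrophenyl. Among the compounds with values here, no measured step of this kind exists. An exchange of methyl for nitro is expected to move the value downward, by a step of moderate size that goes beyond the scatter, so the expected step from compound 2 to compound 3 is a number 0.79 log units lower from compound 2 to compound 3 (beyond the scatter). Compound 3 is therefore estimated at 2.85, within 2.4 to 3.3, because compound 2 gives 3.64 as the starting point.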

Compound 3, partition coefficient: 3.15
Compound 3: the middle estimate sits 0.30 log units below what was measured; the range from low to high includes it.
By their numbers in this assay, from the lowest: compound 1; then compound 3; then compound 2.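

In this assay, within the data shown here, nitro in place of methyl on an aromatic carbon para to a large group gives a number 0.49 log units lower from compound 2 to compound 3 (beyond the scatter) and this is the first single-point step. Among these compounds, the step is modest, yet it shows that the value responds to a change at this place on the aryl arm, which the earlier compounds, with no single-point link between them, could not show. No measurement at hand bears on why the step has this size.

Still open, on these data alone, is how an amine or a carboxylic acid at this same aromatic carbon would compare with methyl and nitro. Also open, as far as these compounds go, is whether the exchange of 4-methylphenyl for 4-nitrophenyl gives a step of similar size on another member of the series.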